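A few compounds are considered here, and "the series" means these few. Any claim that something is new, unique, unknown or untested is made for them only; others in the source may bear on it.

In a functional assay on MCF7 cells (Homo sapiens) for inhibition, read by sulforhodamine B assay, with a stated time of 48 h, tested at 50 uM (on this read-out lower numbers stand for less inhibition of growth and higher numbers for more inhibition of growth at the one concentration tested), compound 1 (`COc1ccc([C@@H]2C/C(=N/OCc3cn(-c4ccc(O)cc4)nn3)c3cc(CC=C(C)C)c(OC)cc3O2)cc1`) gives 63%, compound 2 (`COc1ccc([C@@H]2C/C(=N/OCc3cn(-c4ccc(C(=O)c5ccccc5)cc4)nn3)c3cc(CC=C(C)C)c(OC)cc3O2)cc1`) gives 41% and compound 3 (`COc1ccc([C@@H]2C/C(=N/OCc3cn(-c4ccc(Cl)cc4C)nn3)c3cc(CC=C(C)C)c(OC)cc3O2)cc1`) gives 37%. Compound 3 thus lies within the scatter of compound 2, and both stand clearly under compound 1. Compound 4 (`COc1ccc([C@@H]2C/C(=N/OCc3cn(-c4ccc(C(N)=O)cc4)nn3)c3cc(CC=C(C)C)c(OC)cc3O2)cc1`) carries 4-carbamoylphenyl in place of 4-chloro-2-methylphenyl on an aromatic nitrogen. Two measured steps change this same aryl group, a number 22 percentage points lower from compound 1 to compound 2 (beyond the scatter) and a number 26 percentage points lower from compound 1 to compound 3 (beyond the scatter), both modest and beyond the scatter. Neither tests a carbamoyl group directly, so the expectation rests on the span they mark out. A small rise is expected, a number 11 percentage points higher from compound 3 to compound 4 (beyond the scatter). The estimated value for compound 4 is 48%, with an expected range from 33% to 63%.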

Compound 4, percent growth inhibition at one concentration: 100%
Beside the measured number, compound 4's estimate is 52 percentage points below it; the whole stated range lies below it.
By their numbers in this assay, from the lowest: compounds 3 and 2 (each within the scatter of the next); then compound 1; then compound 4.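

In this assay the aryl group on the aromatic nitrogen proves able to raise the number as well as lower it: 4-carbamoylphenyl in place of 4-chloro-2-methylphenyl gives a number 63 percentage points higher from compound 3 to compound 4 (beyond the scatter) and carbamoyl in place of hydroxy gives a number 37 percentage points higher from compound 1 to compound 4 (beyond the scatter). What sits on the carbonyl carbon also counts, since amino in place of phenyl gives a number 59 percentage points higher from compound 2 to compound 4 (beyond the scatter). Nothing at hand explains these rises. The compounds shown leave open whether a carboxylic acid, a nitrile or a methyl amide on this phenyl ring would give a similar number.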